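Swapping cyclohexyl for propyl on the urea nitrogen

A few compounds are considered here, and "the series" means these few. Any claim that something is new, unique, unknown or untested is made for them only; others in the source may bear on it.

Measured compounds:
compound 1 `O=C(NC1CCCCC1)NS(=O)(=O)N1CCC(CCNC(=O)c2nsc3ccccc23)CC1` gives 17% in a functional assay on the whole organism (blood) with Rattus norvegicus as the target, with stated times of 24 h and 1 h, at a dose of 15 mg/kg by the intraperitoneal route; a lower number here means a weaker effect, a higher number a stronger effect of the compound at the dose given;
compound 2 `O=C(NC1CCCCC1)NS(=O)(=O)N1CCC(CCNC(=O)c2cccc3c2OCCO3)CC1` gives 42%.

Within the data shown here, compound 2 stands highest of the two measured compounds in this assay; the only other value is that of compound 1, and the step of a number 25 percentage points higher from compound 1 to compound 2 (beyond the scatter) lies beyond the scatter. Compound 3 `CCCNC(=O)NS(=O)(=O)N1CCC(CCNC(=O)c2cccc3c2OCCO3)CC1` has not yet been measured. It differs from compound 2 in one place: propyl in place of cyclohexyl on an amide-type nitrogen. Among the measured compounds shown here, no measured step touches this part of the structure; the one step known changes a group on a carbonyl carbon elsewhere, so it gives no guidance here. For compound 3 the step of a number 7 percentage points lower from compound 2 to compound 3 (within the scatter) is therefore expected to be small, with the direction uncertain and a wide range allowed. Compound 3 is estimated at 35%, between 10% and 60%.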

Compound 3, a percentage reported as activity, at one dose (the size of the read-out at that dose, not a potency): 25%
For compound 3 the middle estimate is 10 percentage points above the measured one; low and high end bracket the measured number.
By their numbers in this assay, from the lowest: compounds 1 and 3 (each within the scatter of the next); then compound 2.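

In this assay the swap of cyclohexyl for propyl on the amide-type nitrogen brings a number 17 percentage points lower from compound 2 to compound 3 (beyond the scatter) and so shows that this end of the molecule also affects the read-out, not only the group on the carbonyl carbon changed in the earlier step. With the rest of the structure held constant, the six-membered carbon ring gives the stronger effect at the dose tested, though this rests on a single pair of compounds. Nothing available explains the drop.

Still open, from the compounds shown here alone, is where groups such as cyclopentyl, phenyl or a longer chain such as hexyl would fall relative to cyclohexyl and propyl. Going by these compounds, it is also open whether the swap would have a similar effect with the group on the carbonyl carbon of compound 1.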